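The source may report more compounds than this note shows. Statements on the series, on what has been measured and on what is new or still open speak of the compounds shown alone.

Working notes on the series. Compound 1 `Cc1ccc(-c2nn(-c3ccccc3)cc2C(=O)NOCc2ccccc2F)cc1` and compound 2 `Cc1ccc(-c2nn(-c3ccccc3)cc2C(=O)NOCc2ccccc2Cl)cc1` share a core; compound 3 `O=C(NOCc1ccccc1)c1cn(-c2ccccc2)nc1-c1ccc(Cl)cc1` carries a different core, and the difference between the two cores is not broken down here. In an ADME assay on HEK-293T cells (Homo sapiens) for antiproliferative activity, read by MTT assay, with a stated time of 48 h, in the presence of a further agent that is not named here (a higher number here means that more compound is tolerated, a lower number that less compound is tolerated), compound 1 gives 20600 nM, compound 2 gives 38700 nM and compound 3 gives 51900 nM.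

One change recurs. Between compound 2 and compound 1 it is fluoro in place of chloro on an aromatic carbon, and in this assay it made a 1.9-fold lower number from compound 2 to compound 1 (0.27 log units; within the scatter). Compound 4 `O=C(NOCc1ccccc1)c1cn(-c2ccccc2)nc1-c1ccc(F)cc1`, not yet measured, arises from compound 3 by fluoro in place of chloro on an aromatic carbon. This is the same kind of change, not the same one: in compound 1 the fluoro stands ortho to a large group, in compound 4 it stands para to a large group, and the rest of the molecule differs as well.

Because a 1.9-fold lower number from compound 2 to compound 1 (0.27 log units; within the scatter) stayed within the scatter, the step from compound 3 to compound 4 in this assay is expected to be small as well, estimated as a 1.5-fold lower number from compound 3 to compound 4 (0.17 log units; within the scatter). Compound 4 is thus expected to give about 35000 nM in this assay, with a likely range from 18000 nM to 70000 nM.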

Compound 4, half-maximal cytotoxic concentration: 217000 nM
The estimate for compound 4 lay 6.2-fold (0.79 log units) below the measured number, outside the stated range (above it).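

In this assay, fluoro in place of chloro on an aromatic carbon gives a 4.2-fold higher number from compound 3 to compound 4 (0.62 log units; beyond the scatter). The step seen on one core therefore cannot be carried over to the other in this series, not even as a rough estimate of size: the same change on two cores in this assay, a 1.9-fold lower number (0.27 log units; within the scatter) from compound 2 to compound 1 and a 4.2-fold higher number (0.62 log units; beyond the scatter) from compound 3 to compound 4, 7.9-fold (0.90 log units) apart, beyond the scatter of two such steps What sets the two steps apart is not shown: the two pairs differ both in where the halogen stands and in the rest of the molecule, and two pairs alone cannot separate these.

The compounds shown leave open whether the change from 4-chlorophenyl to 4-fluorophenyl would give a similar step on the core of compound 1, which would separate the place of the halogen from the effect of the core. They also leave open how this assay would read with a methoxy group or an amine in place of the halogen, on an aromatic carbon para to a large group.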